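The source may report more compounds than this note shows. Statements on the series, on what has been measured and on what is new or still open speak of the compounds shown alone.

Compound 1 `COc1ccc(/C=C(/Sc2ccc(C)cc2)C(=O)c2ccc(Cl)cc2)cc1O` and compound 3 `COc1ccc(/C=C(\C(=O)c2ccc(Cl)cc2)S(=O)(=O)c2ccc(C)cc2)cc1O` share one core. In a functional assay on DU-145 cells (Homo sapiens) for inhibition, read by trypan blue exclusion, with a stated time of 96 h (a higher number here means a weaker inhibitor of growth, a lower number a stronger inhibitor of growth), compound 1 gives 1000 nM, and compound 3 gives 1000 nM. The change between them, ((4-methylphenyl)sulfonyl in place of (4-methylphenyl)sulfanyl on a double-bonded chain carbon bound to a carbonyl carbon and a double-bonded chain carbon), made a step of no change at the digits printed from compound 1 to compound 3 (within the scatter). Compound 2 `CCOc1ccc(/C=C(/Sc2ccc(C)cc2)C(=O)c2ccc(Br)cc2)cc1OC` rests on a different core; the difference between the two cores is not broken down here. In this assay compound 2 gives 50000 nM, the highest of the three numbers. Compound 4 `CCOc1ccc(/C=C(\C(=O)c2ccc(Br)cc2)S(=O)(=O)c2ccc(C)cc2)cc1OC` has not yet been measured; it differs from compound 2 by (4-methylphenyl)sulfonyl in place of (4-methylphenyl)sulfanyl on a double-bonded chain carbon bound to a carbonyl carbon and a double-bonded chain carbon, the same change at the same place as the one already seen. That earlier step, no change at the digits printed from compound 1 to compound 3 (within the scatter), is the basis for the expectation. In this assay the expected step is therefore no change at the digits printed from compound 2 to compound 4 (within the scatter). Compound 4 is estimated at 50000 nM, with a likely range from 20000 nM to 120000 nM.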

Compound 4, concentration for 50% growth inhibition: 1000 nM
Compound 4: middle estimate off by 50-fold (1.70 log units), on the high side; the measured number lies below the stated range.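

In this assay, putting (4-methylphenyl)sulfonyl in place of (4-methylphenyl)sulfanyl gave a 50-fold lower number from compound 2 to compound 4 (1.70 log units; beyond the scatter), so the outcome of this change did not carry over from one core to the other: the same change on two cores in this assay, no change at the digits printed (within the scatter) from compound 1 to compound 3 and a 50-fold lower number (1.70 log units; beyond the scatter) from compound 2 to compound 4, 50-fold (1.70 log units) apart, beyond the scatter of two such steps
This shows that, in these two pairs, the size of the step depended on the core that carried the change. It does not show which difference between the two cores is responsible, and two pairs give no rule for any other core.

The compounds shown leave open how the same change would behave on a core bearing an amine or a carboxylic acid. They also leave open what an amide would do on that double-bonded chain carbon.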